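Chloro/trifluoromethyl pairing on the aryl ring of compound 2

The source may report more compounds than this note shows. Statements on the series, on what has been measured and on what is new or still open speak of the compounds shown alone.

Of the compounds shown here, three have been measured in an assay for binding affinity to Corticotropin releasing factor receptor (Rattus norvegicus); on this read-out higher numbers stand for weaker inhibition and lower numbers for stronger inhibition. Compound 1 `CCCC(C)n1c(CC)nc2c(-c3ccc(S(C)(=O)=O)cc3C(F)(F)F)ccnc21` gives 6.8 nM. Compound 2 `CCCC(C)n1c(CC)nc2c(-c3ccc(C(C)OC)cc3Cl)ccnc21` gives 3.5 nM, the second highest of the three numbers; the gap to compound 1 lies within the scatter, so no order is claimed between these two. Compound 3 `CCc1nc2c(-c3ccc(Cl)cc3Cl)ccnc2n1C(C)C1CCC1` gives 1 nM, which stands beyond the scatter below compound 2 and is the lowest of the three.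

Compound 4 `CCCC(C)n1c(CC)nc2c(-c3ccc(C(F)(F)F)cc3Cl)ccnc21` has not yet been measured. It differs from compound 2 in one place, (trifluoromethyl in place of 1-methoxyethyl on an aromatic carbon), the trifluoromethyl sitting meta to a chloro group and para to a large group. Among the compounds with values here, no step between measured compounds covers this exact exchange. Compound 1 carries a trifluoromethyl on its aryl ring together with a different partner group and a number not far from that of compound 2, while compound 3 carries two chloro groups and the lowest number; neither pair isolates the exchange in question.

The step from compound 2 to compound 4 is therefore expected to be small, a 1.2-fold lower number from compound 2 to compound 4 (0.07 log units; within the scatter), with no clear direction beyond the scatter. For compound 4 the estimate in this assay is 3 nM, with a range from 1 nM to 9 nM.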

Compound 4, inhibition constant: 1.1 nM
The estimate for compound 4 lay 2.7-fold (0.44 log units) above the measured number, within the range that was stated.
By their numbers in this assay, from the lowest: compounds 3 and 4 (each within the scatter of the next); then compounds 2 and 1 (each within the scatter of the next).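

Working notes on this position: at the aromatic carbon meta to a chloro group and para to a large group, trifluoromethyl in place of 1-methoxyethyl is not a neutral exchange in this assay, with a 3.2-fold lower number from compound 2 to compound 4 (0.50 log units; beyond the scatter). The two groups have the same count of heavy atoms and neither has a ring or a net charge, yet the oxygen and the hydrogen-bond acceptor of 1-methoxyethyl leave with it, so this position keeps a low number in this read-out without that acceptor. The data do not establish what causes the step, and no measurement bears on whether the lost acceptor or some other difference between the two groups is responsible.

Open, from the compounds shown here alone, is whether the lower number belongs to trifluoromethyl itself or would also follow from a nitrile, a methoxy group or a primary amine on this aromatic carbon. Also open, going by these compounds, is whether the step would keep its size with a bromo group in place of the chloro group, or with a longer chain in place of the ethyl group on the shared core.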